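A few compounds are considered here, and "the series" means these few. Any claim that something is new, unique, unknown or untested is made for them only; others in the source may bear on it.

Four compounds built on one shared core are compared here. Going by the values given here, compound 1 `COc1cccc(-c2nc(C(F)(F)F)n(CC[C@@H](O)C[C@@H](O)CC(=O)O)c2-c2ccc(F)cc2)c1` and compound 2 `Cc1ccc(-c2nc(C(F)(F)F)n(CC[C@@H](O)C[C@@H](O)CC(=O)O)c2-c2ccc(F)cc2)cc1` are the first pair; compound 3 `COc1cccc(-c2c(-c3ccc(F)cc3)nc(C(F)(F)F)n2CC[C@@H](O)C[C@@H](O)CC(=O)O)c1` carries the same atoms as compound 1 but joined differently, and the difference between these two cores is not broken down here. Compound 4 `Cc1ccc(-c2c(-c3ccc(F)cc3)nc(C(F)(F)F)n2CC[C@@H](O)C[C@@H](O)CC(=O)O)cc1` stands to compound 3 as compound 2 stands to compound 1.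

In an assay on microsomes from liver for inhibition of 3-hydroxy-3-methylglutaryl-coenzyme A reductase (Rattus norvegicus) (a lower number here means a stronger inhibitor, a higher number a weaker inhibitor), compound 1 gives 20 nM. Compound 2 gives 43 nM in this assay, and the change from compound 1 to compound 2 4-methylphenyl in place of 3-methoxyphenyl on an aromatic carbon brought a 2.2-fold higher number from compound 1 to compound 2 (0.33 log units; beyond the scatter). Compound 3 gives 135 nM, the highest number of the three measured compounds.

The change from compound 3 to compound 4 4-methylphenyl in place of 3-methoxyphenyl on an aromatic carbon is the same kind of change as the earlier one, though the place is not the same word for word: in compound 3 it is next to the ring atom that bears a 6-carboxy-3,5-dihydroxyhexyl group, whereas in compound 1 it is two ring bonds from that ring atom. Among the compounds with values here, with only one earlier example of the change, the expectation rests on compound 1 and compound 2 alone, so a step of about the same size is expected, namely a 2.1-fold higher number from compound 3 to compound 4 (0.32 log units; beyond the scatter). Compound 4 is therefore estimated at 280 nM in this assay, with a range from 120 nM to 650 nM.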

Compound 4, half-maximal inhibitory concentration: 750 nM
Compound 4: the middle estimate sits 2.7-fold (0.43 log units) below what was measured, and the stated range ends below it.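

In this assay, putting 4-methylphenyl in place of 3-methoxyphenyl on the second core again gives a weaker inhibitor, with a 5.6-fold higher number from compound 3 to compound 4 (0.74 log units; beyond the scatter), so the change points the same way on both cores. The second step looks larger than the first, but the two cannot be told apart: the same change on two cores in this assay, a 2.2-fold higher number (0.33 log units; beyond the scatter) from compound 1 to compound 2 and a 5.6-fold higher number (0.74 log units; beyond the scatter) from compound 3 to compound 4, 2.6-fold (0.41 log units) apart, within the scatter of two such steps The change therefore carries over from the core of compound 1 to the core of compound 3 in direction and, as far as these two pairs can tell, in size, but two pairs make no general rule for other cores, and they do not explain why either step occurs.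

From the compounds shown here alone, each pair compares only 3-methoxyphenyl with 4-methylphenyl, which differ in both the group and where it sits on the phenyl ring, so it remains open how 3-methylphenyl or 4-methoxyphenyl would compare and which of those two differences matters. Going by these compounds, the trifluoromethyl, 4-fluorophenyl and 6-carboxy-3,5-dihydroxyhexyl groups stay the same throughout, so it is also open whether the step would hold with an isopropyl group in place of trifluoromethyl.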